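The source may hold more compounds than are shown below. What is called first, only, known or untested is meant among the compounds shown, and "the series" means these compounds.

Measured compounds and values:

compound 1 `O=C(/C=C/c1ccc2c(c1)B(O)OC2)c1ccccn1` — > 10 ug/mL
compound 2 `COc1cccc(C(=O)/C=C/c2ccccc2)c1` — 5.7 ug/mL
compound 3 `O=C(/C=C/c1ccc2c(c1)B(O)OC2)c1ccc(Cl)c(Cl)c1` — > 10 ug/mL

In an ADME assay on L929 cells (Mus musculus) for cytotoxicity, read by resazurin assay, with a stated time of 72 h (a lower number here means a stronger inhibitor, a higher number a weaker inhibitor), compound 1 gives > 10 ug/mL, which is a limit of the assay and not a number. Compound 3 also gives > 10 ug/mL, again only a limit. Compound 2 gives 5.7 ug/mL. Compound 1 therefore stands at the limit of > 10 ug/mL in this assay, at which 2 of the 3 values shown sit, so its true value is not pinned down. Compound 4 `O=C(/C=C/c1ccc2c(c1)B(O)OC2)c1ccc(O)cc1` differs from compound 1 in one place: 4-hydroxyphenyl in place of pyridin-2-yl on a carbonyl carbon. Going by the values given here, no measured pair in this set shows this change, so the size of the step in this assay is unknown; given that compound 1 and compound 3 both sit at the limit, compound 4 is expected to stay near it, with a step of an at least 1.1-fold lower number from compound 1 to compound 4 (0.04 log units; that floor lies within the scatter) hardly beyond the scatter. Compound 4 is estimated at 9 ug/mL, between 4 ug/mL and 20 ug/mL.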

Compound 4, half-maximal inhibitory concentration: > 10 ug/mL
Compound 4 was reported as a limit; the forecaster's own chance of this, stated with the estimate: 60%; middle value at least 1.1-fold (0.04 log units) away from the limit.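

Compound 1 and compound 4 both give only a limit of the assay in this assay, so no step between them can be read: the limit of > 10 ug/mL in this assay, at which 3 of the 4 values shown sit.

The compounds shown leave open how 4-hydroxyphenyl in place of pyridin-2-yl on a carbonyl carbon acts on the true values.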